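This account rests on a few compounds, and the source may have more. Where it says the series, first, only, none or still open, it means among the compounds named here.

Measured compounds in an ADME assay on T29 cells (Homo sapiens) for cytotoxicity, read by sulforhodamine B assay, with a stated time of 3 days; a lower number here means a stronger inhibitor, a higher number a weaker inhibitor:
- compound 1, `O=Cc1cn(Cc2cccc(Br)c2)c2ccccc12`: compound 1 gives > 31600 nM, which is a limit of the assay and not a number.
- compound 2, `OCc1cn(Cc2ccccc2)c2ccccc12`: compound 2 gives 14500 nM.
- compound 3, `OCc1cn(Cc2cccc(Cl)c2)c2ccccc12`: compound 3 gives > 31600 nM, again a limit of the assay rather than a number.

Compound 3 therefore stands at the weak end of what has been measured, with only a limit to its name; it shares that limit with compound 1 (the limit of > 31600 nM in this assay, at which 2 of the 3 values shown sit). For the measured compounds named here, the one step measured is an at least 2.1-fold higher number from compound 2 to compound 3 (0.33 log units; beyond the scatter), which moves a compound from a measured number up to the limit.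

Compound 4 is `OCc1cn(Cc2cccc(Br)c2)c2ccccc12`. Against compound 3 the change is bromo in place of chloro on an aromatic carbon. Going by the values given here, no measured pair differs by bromo in place of chloro, so nothing bears directly on this step; the closest evidence is that compound 1, which also carries bromo on the same ring, sits at the limit, and that compound 3 already sits at the limit. The expectation for this assay is thus a step that the limit leaves unreadable from compound 3 to compound 4, not beyond the scatter, and most likely a further limit rather than a number. Compound 4 is estimated at 40000 nM, with a range from 15000 nM to 100000 nM.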

Compound 4, half-maximal inhibitory concentration: > 31600 nM
Compound 4 ended at the assay's limit; the forecaster's own chance of this, stated with the estimate: 75%; the middle value is on the limit's open side.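

In this assay, bromo in place of hydrogen on this aromatic carbon, meta to a large group, gives an at least 2.1-fold higher number from compound 2 to compound 4 (0.33 log units; beyond the scatter), so the move away from the unsubstituted ring now holds for a second halogen as well as for chloro, which gave an at least 2.1-fold higher number from compound 2 to compound 3 (0.33 log units; beyond the scatter). The steps from compound 3 to compound 4 and from compound 1 to compound 4 cannot be read, as both ends of each are limits of the assay, so neither bromo against chloro nor hydroxymethyl against formyl can be ranked here. Compound 2 remains the only compound with a measured number, and the three halogen-bearing compounds share one assay limit: the limit of > 31600 nM in this assay, at which 3 of the 4 values shown sit.

As far as these compounds go, the size of the shift that either halogen brings remains unknown, and so does any difference between them, since the readings stop at the limit and only a lower bound on each step from compound 2 is available. Also open, from the compounds shown here alone, is whether an amine or a carboxylic acid on this aromatic carbon would give a measured number, as compound 2 does, or would end at the same limit as the halogens.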